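This account rests on a few compounds, and the source may have more. Where it says the series, first, only, none or still open, it means among the compounds named here.

Compound 1 `CN(C)CCCn1c(N)c(-c2nc3cc(Cl)ccc3[nH]2)c2nc(C#N)c(C#N)nc21`, compound 2 `CCN(CC)CCCn1c(N)c(-c2nc3cc(Cl)ccc3[nH]2)c2nc(C#N)c(C#N)nc21` and compound 3 `CN(C)CCCCn1c(N)c(-c2nc3cc(Cl)ccc3[nH]2)c2nc(C#N)c(C#N)nc21` share one core. In a functional assay on A549 cells (Homo sapiens) for antiproliferative activity, read by MTT assay, with a stated time of 48 h (a lower number here means a stronger inhibitor, a higher number a weaker inhibitor), compound 1 gives > 50000 nM, a limit of the assay. Compound 2 gives > 50000 nM, also a limit and not a number. Among the compounds with values here, that leaves the series so far at the limit of > 50000 nM in this assay, at which 2 of the 2 values shown sit. Compound 3 differs from compound 2 by (dimethylamino)methyl in place of diethylamino on a saturated chain carbon, three bonds along the chain from an aromatic nitrogen. Within the data shown here, the one measured step bearing on this change is a step that the two limits leave unreadable from compound 1 to compound 2. No step beyond the scatter is therefore expected in this assay, and another limit is likely. The expected change is a number no higher from compound 2 to compound 3 (the limit leaves the size open). For compound 3 the estimate is 50000 nM, with an expected range of 15000 nM to 100000 nM.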

Compound 3, half-maximal inhibitory concentration: 12100 nM
The estimate for compound 3 lay 4.1-fold (0.62 log units) above the measured number, outside the stated range (below it).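

In this assay, within the data shown here, replacing 3-(dimethylamino)propyl with 4-(dimethylamino)butyl on the aromatic nitrogen gives an at least 4.1-fold lower number from compound 1 to compound 3 (0.61 log units; beyond the scatter), the first readable number. Replacing 3-(diethylamino)propyl with the same group gives an at least 4.1-fold lower number from compound 2 to compound 3 (0.61 log units; beyond the scatter). The step from compound 1 to compound 2 cannot be read, and the shorter chains stay at a limit: the limit of > 50000 nM in this assay, at which 2 of the 3 values shown sit.

Going by these compounds, whether 4-(diethylamino)butyl would give a number close to that of compound 3 remains open. So does whether a longer chain ending in dimethylamino would lower the number further.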